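Series notes: 2,4-dichlorophenyl replacing 4-methylphenyl

This account rests on a few compounds, and the source may have more. Where it says the series, first, only, none or still open, it means among the compounds named here.

Measured compounds:
compound 1 `COc1cc2c(Oc3ccc(NC(=O)c4cc(-c5ccccc5)nc5ccccc45)cc3F)ccnc2cc1OCCCN1CCCCC1` gives 530 nM
compound 2 `COc1cccc(-c2cc(C(=O)Nc3ccc(Oc4ccnc5cc(OCCCN6CCCCC6)c(OC)cc45)c(F)c3)c3cc(F)ccc3n2)c1` gives 2500 nM
compound 3 `COc1cc2c(Oc3ccc(NC(=O)c4cc(-c5ccc(C)cc5)nc5ccc(F)cc45)cc3F)ccnc2cc1OCCCN1CCCCC1` gives 500 nM

In a functional assay on HT-29 cells (Homo sapiens) for cytotoxicity, read by MTT assay, with a stated time of 72 h (on this read-out lower numbers stand for stronger inhibition and higher numbers for weaker inhibition), compound 3 gives the lowest of the three numbers; compound 1 lies within the scatter of it, compound 2 beyond it. Within the data shown here, the only aryl change measured so far is a 5.0-fold lower number from compound 2 to compound 3 (0.70 log units; beyond the scatter). Compound 4 `COc1cc2c(Oc3ccc(NC(=O)c4cc(-c5ccc(Cl)cc5Cl)nc5ccc(F)cc45)cc3F)ccnc2cc1OCCCN1CCCCC1` carries 2,4-dichlorophenyl in place of 4-methylphenyl on an aromatic carbon. Among the measured compounds shown here, no measured pair shows a chlorinated aryl at this place, so the step from compound 2 to compound 3 is the only guide, and it shows how far such a swap can move the number. For compound 4 a step of a 1.4-fold higher number from compound 3 to compound 4 (0.15 log units; within the scatter) is expected, within the scatter of compound 3. The estimate for compound 4 is 700 nM, with a range of 250 nM to 2500 nM.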

Compound 4, half-maximal inhibitory concentration: 530 nM
For compound 4 the middle estimate is 1.3-fold (0.12 log units) above the measured one, and the stated range covers the measured number.
By their numbers in this assay, from the lowest: compounds 3, 1 and 4 (each within the scatter of the next); then compound 2.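

In this assay the first chlorinated aryl at this place leaves the number unchanged: a 1.1-fold higher number from compound 3 to compound 4 (0.03 log units; within the scatter) lies within the scatter, so 2,4-dichlorophenyl and 4-methylphenyl cannot be told apart here. Against 3-methoxyphenyl, a 4.7-fold lower number from compound 2 to compound 4 (0.67 log units; beyond the scatter) lies beyond the scatter, so compound 2 now stands apart from two differently substituted aryl groups, not one. Nothing measured here explains either step. Open, on these data alone, is how 4-chlorophenyl or 2-chlorophenyl would read, showing whether one chlorine suffices, and whether an aryl carrying an amine or a carboxylic acid would hold this level.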